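Notes on the benzyl step from compound 2 to compound 4

The source may report more compounds than this note shows. Statements on the series, on what has been measured and on what is new or still open speak of the compounds shown alone.

- compound 1 `O=C(NO)c1cnc(N2C[C@@H]3[C@H](C2)[C@H]3NS(=O)(=O)c2cccs2)nc1`: > 10000 nM, a limit of the assay
- compound 2 `O=C(NO)c1cnc(N2C[C@@H]3[C@H](C2)[C@H]3NCc2ccccc2)nc1`: 120 nM
- compound 3 `O=C(NO)c1cnc(N2C[C@@H]3[C@H](C2)[C@H]3NCc2ccc(C(F)(F)F)cc2)nc1`: 700 nM
- compound 4 `O=C(NO)c1cnc(N2C[C@@H]3[C@H](C2)[C@H]3NCc2cc(F)cc(F)c2)nc1`: not yet measured

In a functional assay on HCT-116 cells (Homo sapiens) for antiproliferative activity, read by WST assay, with a stated time of 72 h (on this read-out lower numbers stand for stronger inhibition of growth and higher numbers for weaker inhibition of growth), compound 2 gives 120 nM, the lower of the two exact numbers, with compound 3 at 700 nM. The change under study is 3,5-difluorophenyl in place of phenyl on a saturated chain carbon bound to an amine nitrogen. Going by the values given here, the closest precedent is the modest 5.8-fold higher number from compound 2 to compound 3 (0.77 log units; beyond the scatter), also a substitution on an aromatic carbon. The large at least 83-fold lower number from compound 1 to compound 2 (1.92 log units; beyond the scatter) replaces the whole group on the amine nitrogen and ends at a limit, so it says little here. On that single precedent, a smaller rise in this assay is expected, possibly within the scatter. The expected change is a 1.7-fold higher number from compound 2 to compound 4 (0.22 log units; within the scatter). Compound 4 is estimated at 200 nM, with an expected range of 80 nM to 500 nM.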

Compound 4, concentration for 50% growth inhibition: 200 nM
Beside the measured number, compound 4's estimate shows no gap at the digits printed; measured number inside the range.
By their numbers in this assay, from the lowest: compounds 2 and 4 (each within the scatter of the next); then compound 3. At a limit, above all of these: compound 1.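

In this assay, the new step, a 1.7-fold higher number from compound 2 to compound 4 (0.22 log units; within the scatter), shows that the phenyl on this saturated chain carbon bound to an amine nitrogen can give way to 3,5-difluorophenyl without a change beyond the scatter. The earlier substitution on the aromatic ring, a 5.8-fold higher number from compound 2 to compound 3 (0.77 log units; beyond the scatter), did go beyond the scatter, so the outcome at this ring depends on the group entering. Nothing shown gives a cause for the difference between these two steps.

Still open, going by these compounds, is how an amine or a carboxylic acid on this phenyl ring, or a longer chain in place of the benzyl, would read in this assay.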